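A few compounds are considered here, and "the series" means these few. Any claim that something is new, unique, unknown or untested is made for them only; others in the source may bear on it.

Measured so far:
compound 1 `COc1cccc(C(=O)N2CCCCC2CCOc2ccc(Cl)c(Cl)c2)c1` gives 126 nM in a functional assay on CHO cells for antagonist activity at Orexin/Hypocretin receptor type 1 (Homo sapiens), read by FLIPR; on this read-out lower numbers stand for stronger inhibition and higher numbers for weaker inhibition
compound 2 `O=C(C[C@@H]1CCCCN1C(=O)c1ccccc1-c1ccccc1)Nc1ccccc1` gives 50.1 nM in this assay

Compound 2 holds the lower of the two numbers in this assay; compound 1 sits above it by a gap beyond the scatter. Compound 3 `O=C(NC[C@@H]1CCCCN1C(=O)c1ccccc1-c1ccccc1)Nc1ccccc1` differs from compound 2 by (phenylcarbamoyl)amino in place of phenylcarbamoyl on a saturated chain carbon bound to a saturated ring carbon. Among the compounds with values here, no step between measured compounds covers this change, so any expectation rests on compound 2 alone. A step of modest size is expected, with no direction that clearly exceeds the scatter, namely a 1.6-fold higher number from compound 2 to compound 3 (0.20 log units; within the scatter). For compound 3 the estimated value in this assay is 80 nM, expected to fall between 20 nM and 320 nM.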

Compound 3, inhibition constant: 1 nM
For compound 3 the middle estimate is 80-fold (1.90 log units) above the measured one, outside the stated range (below it).
By their numbers in this assay, from the lowest: compound 3; then compound 2; then compound 1.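

On a saturated chain carbon bound to a saturated ring carbon, (phenylcarbamoyl)amino in place of phenylcarbamoyl gives a 50-fold lower number from compound 2 to compound 3 (1.70 log units; beyond the scatter) in this assay. This position is therefore highly sensitive to the change, although both groups carry the same aromatic ring and the entering group differs by one added nitrogen and 2 hydrogen-bond donors rather than 1. Nothing available explains a step of this size.

On these data alone, whether a carbamate or a longer chain at this place would keep the lower number remains open. So does whether the step carries over to a core other than the one shared by these compounds.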